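This account rests on a few compounds, and the source may have more. Where it says the series, first, only, none or still open, it means among the compounds named here.

Measured so far:
compound 1 `CC1=C(N2CC2)C(=O)C(COc2ccccc2)=C(N2CC2)C1=O` — 3.89
compound 2 `CC1=C(N2CC2)C(=O)C(CCCc2ccccc2)=C(N2CC2)C1=O` — 3.6
compound 3 `COCCC1=C(N2CC2)C(=O)C(C)=C(N2CC2)C1=O` — 5.12

The three measured compounds share one core and differ only in the chain on it. Read in a functional assay on L1210 cells (Mus musculus), with a stated time of 1 days (on this read-out higher numbers stand for higher potency (the scale is a negative logarithm) and lower numbers for lower potency), compound 3 stands highest of the three: the step of a number 1.23 log units higher from compound 1 to compound 3 (beyond the scatter) and the step of a number 1.52 log units higher from compound 2 to compound 3 (beyond the scatter) both lie well beyond the scatter, while between the two aryl-bearing compounds the step of a number 0.29 log units lower from compound 1 to compound 2 (within the scatter) is within the scatter.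

Compound 4 `CC1=C(N2CC2)C(=O)C(CCCOC(N)=O)=C(N2CC2)C1=O` has not yet been measured. It differs from compound 3 by one change: (carbamoyloxy)methyl in place of methoxy on a saturated chain carbon, two bonds along the chain from a double-bonded ring carbon. Among the measured compounds shown here, none of the measured steps makes this exact exchange. The two steps that bear on it, from compound 2 to compound 3 and from compound 1 to compound 3, show that the small methoxy-bearing chain gave a large gain over chains ending in a phenyl ring; the entering (carbamoyloxy)methyl group carries no ring but is larger than the methoxy it replaces and adds a hydrogen-bond donor. Because the gains of a number 1.52 log units higher from compound 2 to compound 3 (beyond the scatter) and a number 1.23 log units higher from compound 1 to compound 3 (beyond the scatter) came with removal of the ring rather than with chain length as such, compound 4 is expected to stay near compound 3, with the step of a number 0.08 log units higher from compound 3 to compound 4 (within the scatter) estimated as within the scatter. Compound 4 is thus estimated at 5.2 in this assay, in a range from 4.5 to 5.9.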

Compound 4, logarithm of the reciprocal of the active concentration, log(1/C): 5.48
Estimate against measurement, compound 4: 0.28 log units below; low and high end bracket the measured number.
By their numbers in this assay, from the lowest: compounds 2 and 1 (each within the scatter of the next); then compound 3; then compound 4.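

Compound 4 shows that, in this assay, this position takes the larger 2-(carbamoyloxy)ethyl chain without any loss relative to the methoxy-bearing chain: the exchange gives a number 0.36 log units higher from compound 3 to compound 4 (beyond the scatter), a modest step that leaves compound 4 highest of the four. The distance to the chains ending in a phenyl ring also grows, with a number 1.88 log units higher from compound 2 to compound 4 (beyond the scatter) and a number 1.59 log units higher from compound 1 to compound 4 (beyond the scatter), so both chains without a ring now stand well above both chains with one, and none of the four compounds goes against this. Nothing shown here gives a measured reason for these differences.

The compounds shown leave open whether the modest gain belongs to the whole carbamoyloxy group or to one part of it, which a 2-hydroxyethyl chain or a plain propyl chain at the same place could help to separate. They also leave open how an amine or a carboxylic acid at the end of this chain would read, and whether a longer chain carrying the same carbamoyloxy group would hold the number of compound 4.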